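A few compounds are considered here, and "the series" means these few. Any claim that something is new, unique, unknown or untested is made for them only; others in the source may bear on it.

Measured so far in an assay on microsomes from liver for inhibition of 3-hydroxy-3-methylglutaryl-coenzyme A reductase (Rattus norvegicus); on this read-out lower numbers stand for stronger inhibition and higher numbers for weaker inhibition:
- compound 1, `O=C(O)C[C@H](O)C[C@H](O)CCn1c(C(F)(F)F)nc(-c2cccs2)c1-c1ccc(F)cc1`: 64 nM
- compound 2, `O=C(O)C[C@H](O)C[C@H](O)CCn1c(C(F)(F)F)nc(-c2cccnc2)c1-c1ccc(F)cc1`: 66 nM
- compound 3, `O=C(O)C[C@H](O)C[C@H](O)CCn1c(C(F)(F)F)nc(-c2ccc(F)cc2)c1-c1cccs1`: 215 nM

Compounds 1 and 2 differ in one place, (pyridin-3-yl in place of thiophen-2-yl on an aromatic carbon), and this change gave a 1.0-fold higher number from compound 1 to compound 2 (0.01 log units; within the scatter). Compound 3 has the same atoms as compound 1 joined differently; how the two cores differ is not broken down here, and its number in this assay is the highest of the three.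

Compound 4, `O=C(O)C[C@H](O)C[C@H](O)CCn1c(C(F)(F)F)nc(-c2ccc(F)cc2)c1-c1cccnc1`, is not yet measured. It arises from compound 3 by pyridin-3-yl in place of thiophen-2-yl on an aromatic carbon, the same kind of change as from compound 1 to compound 2, though not the same: here the place is next to the ring atom that bears a large group, whereas in the earlier pair it was two ring bonds from that atom. Resting on the small step seen from compound 1 to compound 2 in this assay, the step from compound 3 to compound 4 is expected to be a 1.1-fold lower number from compound 3 to compound 4 (0.03 log units; within the scatter). Compound 4 is therefore estimated at 200 nM, with a range from 90 nM to 450 nM.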

Compound 4, half-maximal inhibitory concentration: > 1000 nM
Compound 4 was reported as a limit (the forecaster's own chance of this, stated with the estimate: 0%); middle value at least 5.0-fold (0.69 log units) away from the limit.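

In this assay compound 4 is reported only as a limit, > 1000 nM. Pyridin-3-yl in place of thiophen-2-yl gave an at least 4.6-fold higher number from compound 3 to compound 4 (0.66 log units; beyond the scatter), so the near-silent step seen on the core of compound 1 did not carry over to the core of compound 3: the same change on two cores in this assay, a 1.0-fold higher number (0.01 log units; within the scatter) from compound 1 to compound 2 and an at least 4.6-fold higher number (0.66 log units; beyond the scatter) from compound 3 to compound 4, at least 4.5-fold (0.65 log units) apart, beyond the scatter of two such steps This rests on two pairs, and with a limit on one side the full size of the step stays unknown, as does which difference between the cores sets it apart.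

Open, on these data alone, is how a phenyl group, or a pyridin-4-yl group, next to the ring atom that bears a large group would read in this assay. Such groups could show whether the step follows the six-membered ring or the ring nitrogen.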